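Replacing the Dinitro Ester by a Dimethoxy Ester

The source may hold more compounds than are shown below. What is called first, only, known or untested is meant among the compounds shown, and "the series" means these compounds.

Three esters built on a shared core have been measured so far. Compound 1 `COc1ccc(C(=O)OCC2Oc3ccc([C@H]4Oc5cc(O)cc(O)c5C(=O)[C@@H]4O)cc3OC2c2ccc(O)c(OC)c2)cc1` gives 73300 nM in a functional assay, read by spectrophotometry, with a stated time of 30 min; a lower number here means that less compound is needed, a higher number that more compound is needed for the effect. Compound 2 `COc1cc(C2Oc3cc([C@H]4Oc5cc(O)cc(O)c5C(=O)[C@@H]4O)ccc3OC2COC(=O)c2ccc([N+](=O)[O-])cc2)ccc1O` reaches only the limit of the assay, > 300000 nM, in this assay. Compound 3 `COc1cc(C2Oc3cc([C@H]4Oc5cc(O)cc(O)c5C(=O)[C@@H]4O)ccc3OC2COC(=O)c2cc([N+](=O)[O-])cc([N+](=O)[O-])c2)ccc1O` gives 205000 nM in this assay and stands highest of the two numbers, with compound 1 nearest to it. The measured steps are an at least 4.0-fold higher number from compound 1 to compound 2 (0.61 log units; beyond the scatter), a 2.8-fold higher number from compound 1 to compound 3 (0.45 log units; beyond the scatter) and an at least 1.4-fold lower number from compound 2 to compound 3 (0.16 log units; that floor lies within the scatter), the last two resting on the limit (the limit of > 300000 nM in this assay, at which 1 of the 3 values shown sits).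

Compound 4 `COc1cc(C2Oc3cc([C@H]4Oc5cc(O)cc(O)c5C(=O)[C@@H]4O)ccc3OC2COC(=O)c2ccc(OC)c(OC)c2)ccc1O` differs from compound 3 in one place: 3,4-dimethoxyphenyl in place of 3,5-dinitrophenyl on a carbonyl carbon. Among the measured compounds shown here, this change is essentially the reverse of the step from compound 1 to compound 3, with a second methoxy group added to the aryl ester; the only bearing step is therefore a 2.8-fold higher number from compound 1 to compound 3 (0.45 log units; beyond the scatter). Compound 4 is accordingly expected to return to about the level of compound 1, with a step of a 2.7-fold lower number from compound 3 to compound 4 (0.44 log units; beyond the scatter) in this assay. The estimate for compound 4 in this assay is 75000 nM, with a range from 30000 nM to 180000 nM.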

Compound 4, half-maximal effective concentration: 77000 nM
The estimate for compound 4 lay 1.0-fold (0.01 log units) below the measured number, and the stated range covers the measured number.
By their numbers in this assay, from the lowest: compounds 1 and 4 (each within the scatter of the next); then compound 3. At a limit, above all of these: compound 2.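

At the carbonyl carbon of the ester, exchanging 3,5-dinitrophenyl for 3,4-dimethoxyphenyl in this assay gives a 2.7-fold lower number from compound 3 to compound 4 (0.43 log units; beyond the scatter), so a direct exchange now shows this ester position responding to the aryl group, and the step is beyond the scatter. Adding a second methoxy group to the aromatic ring of the ester gives a 1.1-fold higher number from compound 1 to compound 4 (0.02 log units; within the scatter), which lies within the scatter, so the 4-methoxyphenyl and 3,4-dimethoxyphenyl esters cannot be told apart here, and both methoxy-bearing esters now sit on the lower side of the two nitro-bearing esters. Exchanging 4-nitrophenyl for 3,4-dimethoxyphenyl gives an at least 3.8-fold lower number from compound 2 to compound 4 (0.59 log units; beyond the scatter), a floor and not an exact size, as it rests on a limit: the limit of > 300000 nM in this assay, at which 1 of the 4 values shown sits.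

The four esters leave open whether the gap follows the arrival of methoxy groups or the departure of nitro groups, and a plain phenyl ester would sit between those two readings. Also open, as far as these compounds go, is how this position responds to an aryl ring carrying an amine or a carboxylic acid, or to a longer chain in place of the aryl ring.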